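Methyl for Fluoro on the Aromatic Carbon of Compound 3

The compounds below may be only part of what the source reports. "The series", "measured", "known", "first", "only" and "open" are said of these compounds alone.

Of the compounds shown here, three have so far been tested in an ADME assay on RD cells (Homo sapiens) for cytotoxicity, read by MTT assay, with a stated time of 3 days; on this read-out higher numbers stand for lower toxicity in this test and lower numbers for higher toxicity in this test. Compound 1 `CCC[C@@H](CCn1cncn1)c1ccc(C)cc1` gives 74.1 ug/mL. Compound 2 `CCCC[C@@H](CCn1cncn1)c1ccc(OC)cc1` gives 39.4 ug/mL, and compound 3 `CCCC[C@@H](CCn1cncn1)c1ccc(F)cc1` gives 34.1 ug/mL. Of these three numbers compound 3 stands lowest; compound 2 lies within the scatter of it, whereas compound 1 shows a higher number that lies beyond the scatter. Among the measured compounds shown here, the single step between two compounds differing in one place, a 1.2-fold lower number from compound 2 to compound 3 (0.06 log units; within the scatter), exchanges one group on the aromatic carbon for another and leaves the number essentially where it was.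

Compound 4 `CCCC[C@@H](CCn1cncn1)c1ccc(C)cc1` differs from compound 3 in one place: methyl in place of fluoro on an aromatic carbon. For the measured compounds named here, the only measured step that bears on such an exchange on the aromatic carbon is the one from compound 2 to compound 3, and it was within the scatter. Compound 1 also carries a methyl on its aromatic ring and shows a higher number than compound 3, but it differs from compound 4 elsewhere in its structure, so its value is only a hint. The step of a 1.3-fold higher number from compound 3 to compound 4 (0.12 log units; within the scatter) is therefore expected to be small, possibly toward a higher number. Compound 4 is estimated at 45 ug/mL, with a range from 25 ug/mL to 80 ug/mL.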

Compound 4, half-maximal cytotoxic concentration: 56.5 ug/mL
Estimate against measurement, compound 4: 1.3-fold (0.10 log units) below; measured number inside the range.
By their numbers in this assay, from the lowest: compounds 3, 2, 4 and 1 (each within the scatter of the next, the first and the last beyond it).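

Compound 4 links three single exchanges, and in this assay none of them leaves the scatter. Among the compounds shown here, on the aromatic carbon para to a large group, methyl in place of fluoro gives a 1.7-fold higher number from compound 3 to compound 4 (0.22 log units; within the scatter) and methyl in place of methoxy gives a 1.4-fold higher number from compound 2 to compound 4 (0.16 log units; within the scatter), so, together with the earlier 1.2-fold lower number from compound 2 to compound 3 (0.06 log units; within the scatter), no pair among fluoro, methoxy and methyl is separated beyond the scatter at this position. The comparison with compound 1 adds a second place, as methyl in place of hydrogen on a saturated chain carbon, four bonds along the chain from an aromatic carbon, gives a 1.3-fold lower number from compound 1 to compound 4 (0.12 log units; within the scatter), so the read-out does not separate these two chain lengths either.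

Nothing is available that would account for any of these numbers. On these data alone, it remains open whether an amine, a carboxylic acid or a trifluoromethyl on the aromatic carbon, or a longer chain on the saturated side, would shift the number beyond the scatter.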